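The source may hold more compounds than are shown below. What is called first, only, known or untested is meant among the compounds shown, and "the series" means these compounds.

Compound 1, `CC(O)(CSc1ccc(C(F)(F)F)cc1)C(=O)Nc1cccc(S(F)(F)(F)(F)F)c1`, gives 17500 nM in a functional assay on LNCaP cells (Homo sapiens) for antiproliferative activity, read by propidium iodide staining, with a stated time of 96 h; a higher number here means a weaker inhibitor, a lower number a stronger inhibitor.
Compound 2, `CC(O)(CSc1ccc(OC(F)(F)F)cc1)C(=O)Nc1cccc(S(F)(F)(F)(F)F)c1`, gives 10300 nM in this assay.
Compound 3, `CC(O)(COc1ccc(C(F)(F)F)cc1)C(=O)Nc1cccc(S(F)(F)(F)(F)F)c1`, gives 9600 nM in this assay.

Compound 4, `CC(O)(COc1ccc(OC(F)(F)F)cc1)C(=O)Nc1cccc(S(F)(F)(F)(F)F)c1`, has not yet been measured in this assay. It is made from compound 3 by one change: trifluoromethoxy in place of trifluoromethyl on an aromatic carbon. The very same change, at the same place, has already been made once among these compounds, from compound 1 to compound 2: trifluoromethoxy in place of trifluoromethyl on an aromatic carbon. That earlier step gave a 1.7-fold lower number from compound 1 to compound 2 (0.23 log units; within the scatter). How the core of compound 3 differs from the core of compound 1 is not broken down here; their two values sit within the scatter of each other, so they tell nothing about an order between them.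

Within the data shown here, with only one earlier instance of this change, and that instance within the scatter, the expectation for compound 4 is a small step at most. Compound 4 is expected to give about 7000 nM in this assay, with a likely range from 3500 nM to 14000 nM. This expected step of a 1.4-fold lower number from compound 3 to compound 4 (0.14 log units; within the scatter) rests on the earlier step of a 1.7-fold lower number from compound 1 to compound 2 (0.23 log units; within the scatter), applied to the value of compound 3, 9600 nM.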

Compound 4, half-maximal inhibitory concentration: 12700 nM
For compound 4 the middle estimate is 1.8-fold (0.26 log units) below the measured one; measured number inside the range.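

In this assay, putting trifluoromethoxy in place of trifluoromethyl on this second core gives a 1.3-fold higher number from compound 3 to compound 4 (0.12 log units; within the scatter). Set beside the earlier step, the change shows no measurable difference between the two cores: the same change on two cores in this assay, a 1.7-fold lower number (0.23 log units; within the scatter) from compound 1 to compound 2 and a 1.3-fold higher number (0.12 log units; within the scatter) from compound 3 to compound 4, 2.2-fold (0.35 log units) apart, within the scatter of two such steps. Among these compounds, this shows only that on both cores the change stays within the usual variation between repeat measurements, so it does not show that the change carries a fixed size or direction from one core to another, nor that it has no real effect at all, since two steps this small cannot separate a slight true effect from scatter.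

The compounds shown leave open whether a different group at this place on the aromatic ring, such as an amine, a carboxylic acid or a longer chain, would shift the number beyond the scatter. They also leave open how trifluoromethoxy and trifluoromethyl would compare on a core other than those of compound 1 and compound 3.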